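Aryl variation on the aminothiophene core: nitro replaces hydroxy

The source may report more compounds than this note shows. Statements on the series, on what has been measured and on what is new or still open speak of the compounds shown alone.

Measured so far:
compound 1 `CCOC(=O)c1nn(-c2cccc(Cl)c2)c(=O)c2c(N)scc12`: 5700 nM
compound 2 `CCOC(=O)c1nn(-c2ccc(O)cc2)c(=O)c2c(N)scc12`: 7100 nM

Both values come from an assay on CHO-K1 cells with adenosine receptor A1 (Homo sapiens) as the target; on this read-out lower numbers stand for an effect already at smaller amounts and higher numbers for an effect only at larger amounts of compound. Compound 2 stands at the higher of the two numbers, with compound 1 nearest; the step of a 1.2-fold higher number from compound 1 to compound 2 (0.10 log units; within the scatter) lies within the scatter, so the two compounds cannot be ordered against each other on these data.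

Compound 3 `CCOC(=O)c1nn(-c2ccc([N+](=O)[O-])cc2)c(=O)c2c(N)scc12` is the next member of the series. It differs from compound 2 by nitro in place of hydroxy on an aromatic carbon.

Among the compounds with values here, only one measured step is available, and it concerns the same aromatic carbon ring: a 1.2-fold higher number from compound 1 to compound 2 (0.10 log units; within the scatter). That exchange, between a chlorine-bearing ring and a hydroxy-bearing ring, did not move this assay beyond the scatter. Within the data shown here, no measured pair covers a nitro group, so the bearing of the present exchange on this assay is untested; the sole analogy is that swapping substituents on this ring left the number essentially where it was.

On that basis no step beyond the scatter is expected in this assay, and compound 3 is estimated at 7000 nM, with a range of 2500 nM to 20000 nM. The expected step is a 1.0-fold lower number from compound 2 to compound 3 (0.01 log units; within the scatter).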

Compound 3, half-maximal effective concentration: 13000 nM
Compound 3: middle estimate off by 1.9-fold (0.27 log units), on the low side; measured number inside the range.
By their numbers in this assay, from the lowest: compounds 1, 2 and 3 (each within the scatter of the next, the first and the last beyond it).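

With the place on the ring held fixed, as the earlier pair did not do, nitro in place of hydroxy on an aromatic carbon para to a large group gives in this assay a 1.8-fold higher number from compound 2 to compound 3 (0.26 log units; within the scatter) and so does not separate the two groups at this position. The exchange removes the hydrogen-bond donor of hydroxy and brings in a larger group with more hydrogen-bond acceptors, yet neither difference in these counts is matched by a step beyond the scatter in this assay on this single pair. No measurement is at hand that bears on the reason for this result.

Whether any group at this position can move the number beyond the scatter stays open, since an amine, a carboxylic acid or a methoxy group in the same place is not among the compounds shown. Also open is whether a longer chain in place of the ethyl of the ester would leave the number within the scatter, as the compounds shown all carry that same ester.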